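Furan-3-yl step on the ethyl ester series

The source may hold more compounds than are shown below. What is called first, only, known or untested is meant among the compounds shown, and "the series" means these compounds.

Compound 3 `CCOC(=O)CCCCCOc1cccc(CN(C(=O)c2ccccc2)C(C)C)c1` stands only at a limit of the assay: in an ADME assay on HEK293 cells (Homo sapiens) for cytotoxicity, read by CellTiter-Glo and resazurin assay, with a stated time of 72 h (on this read-out lower numbers stand for an effect already at smaller amounts and higher numbers for an effect only at larger amounts of compound), compound 3 gives > 26000 nM, a limit and not a number. Compound 1 `CC(C)N(Cc1cccc(OCCCCCC(=O)O)c1)C(=O)c1ccccc1` likewise gives only a limit, > 26000 nM, in this assay. Compound 2 `CC(C)N(Cc1cccc(OCCCCCC(=O)O)c1)C(=O)c1ccc(-c2cccc(F)c2)cc1` also gives a limit, > 26000 nM, in this assay. Compound 4 `CCOC(=O)CCCCCOc1cccc(CN(C(=O)c2ccc(-c3ccoc3)cc2)C(C)C)c1` differs from compound 3 by furan-3-yl in place of hydrogen on an aromatic carbon. The measured steps that bear on this change are a step that the two limits leave unreadable from compound 1 to compound 2 and a step that the two limits leave unreadable from compound 1 to compound 3, and neither can be sized because of the limit of > 26000 nM in this assay, at which 3 of the 3 values shown sit. The furan-3-yl entering compound 4 resembles the 3-fluorophenyl entering compound 2, which also arrives at a limit. For compound 4 the expected step that the limit leaves unreadable from compound 3 to compound 4 is none beyond the scatter, most likely again a limit. Compound 4 is therefore estimated at 30000 nM, within 12000 nM to 100000 nM.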

Compound 4, half-maximal effective concentration: > 26000 nM
Compound 4 was reported as a limit; the forecaster's own chance of this, stated with the estimate: 80%; the middle value lies beyond the limit too.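

No step can be read from compound 3 to compound 4, since both values are limits and not numbers: the limit of > 26000 nM in this assay, at which 4 of the 4 values shown sit.

The compounds shown leave open how large the furan-3-yl step is in this assay, and whether any compound here gives a readable value.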